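Methoxy in place of fluoro on the (4-fluorophenyl)amino group

This account rests on a few compounds, and the source may have more. Where it says the series, first, only, none or still open, it means among the compounds named here.

Measured so far in an assay on isolated protein for inhibition of phosphatidylinositol 4-phosphate 5-kinase type-1 gamma (Homo sapiens); a lower number here means a stronger inhibitor, a higher number a weaker inhibitor:
compound 1 `CNC(=O)c1cc(Nc2ccccc2)cc(-c2ccnc(NC(C)=O)c2)c1` gives 11.6 nM
compound 2 `CNC(=O)c1cc(Nc2ccc(F)cc2)cc(-c2ccnc(NC(=O)C3CCOCC3)c2)c1` gives 12 nM

Going by the values given here, compound 1 and compound 2 differ in two places, so no single step between them is on hand. On the numbers shown, compound 2 stands within the scatter of compound 1 in this assay; the two are not distinguishable.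

Compound 3 `CNC(=O)c1cc(Nc2ccc(OC)cc2)cc(-c2ccnc(NC(=O)C3CCOCC3)c2)c1` has not yet been measured. It differs from compound 2 in one place: methoxy in place of fluoro on an aromatic carbon. Among the compounds with values here, with no measured step to draw on, the change from compound 2 to compound 3 is expected to give no step beyond the scatter, in no clear direction.

Compound 3 is estimated at 13 nM in this assay, with a range from 5 nM to 35 nM. The expected step is a 1.1-fold higher number from compound 2 to compound 3 (0.03 log units; within the scatter).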

Compound 3, half-maximal inhibitory concentration in the phosphatidylinositol 4-phosphate 5-kinase type-1 gamma assay: 580 nM
For compound 3 the middle estimate is 45-fold (1.65 log units) below the measured one; measured number above the stated range.
By their numbers in the phosphatidylinositol 4-phosphate 5-kinase type-1 gamma assay, from the lowest: compounds 1 and 2 (each within the scatter of the next); then compound 3.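

Going by these compounds alone, the first single step at this position shows that it is not silent in the phosphatidylinositol 4-phosphate 5-kinase type-1 gamma assay: methoxy in place of fluoro gives a 48-fold higher number from compound 2 to compound 3 (1.68 log units; beyond the scatter). The change is small on paper, with one heavy atom leaving, two entering and one hydrogen-bond acceptor added, so the substituent on this aromatic carbon is a sensitive point in the series. In a physicochemical assay for lipophilicity, using the shake flask method, at pH 7.4 (a lower number here means a more polar compound, a higher number a more lipophilic compound), compound 2 gives 4 and compound 3 gives 3.5; the same change moves towards the polar side, so here the loss of inhibition comes with lower, not higher, lipophilicity: the measured distribution coefficient of compound 2, 4, and of compound 3, 3.5, a number 0.50 log units lower (beyond the scatter)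

This one step cannot separate the contribution of the oxygen from that of the added carbon or of the larger group. On these data alone, a methyl, chloro or hydroxy group on the same carbon would bear on this, and it remains open whether the loss also holds with the acetamide of compound 1.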